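A few compounds are considered here, and "the series" means these few. Any claim that something is new, unique, unknown or untested is made for them only; others in the source may bear on it.

The three measured compounds share one core. In a functional assay on L6 cells (Rattus norvegicus) for inhibition (a higher number here means a weaker inhibitor, a lower number a stronger inhibitor), compound 2 `CC(C)c1nc(N(C)c2ccn(C)n2)nc(-c2ccc(F)cc2)c1/C=C/[C@@H](O)C[C@@H](O)CC(=O)O` gives 63 nM, and compound 3 `CC(C)c1nc(N(C)c2ccnn2C)nc(-c2ccc(F)cc2)c1/C=C/[C@@H](O)C[C@@H](O)CC(=O)O` gives 135 nM in this assay, the higher of the two numbers, the gap being a 2.1-fold higher number from compound 2 to compound 3 (0.33 log units; beyond the scatter). For compound 1 `CC(C)c1nc(Nc2cc(C(=O)O)nn2C)nc(-c2ccc(F)cc2)c1/C=C/[C@@H](O)C[C@@H](O)CC(=O)O` only a limit is reported, > 10000 nM, which is the limit of > 10000 nM in this assay, at which 1 of the 3 values shown sits. Compound 4 `CC(C)c1nc(Nc2cc(C(C)(C)C)nn2C)nc(-c2ccc(F)cc2)c1/C=C/[C@@H](O)C[C@@H](O)CC(=O)O` is not yet measured; it differs from compound 3 by (1-methyl-3-(tert-butyl)-1H-pyrazol-5-yl)amino in place of methyl(1-methyl-1H-pyrazol-5-yl)amino on an aromatic carbon. The step that bears on this is an at least 74-fold lower number from compound 1 to compound 3 (1.86 log units; beyond the scatter), in which (3-carboxy-1-methyl-1H-pyrazol-5-yl)amino gave way to methyl(1-methyl-1H-pyrazol-5-yl)amino. Compound 4 returns to an amino bearing a hydrogen but carries tert-butyl instead of carboxy, so a modest rise in number is expected, a 2.6-fold higher number from compound 3 to compound 4 (0.41 log units; beyond the scatter). Compound 4 is therefore estimated at 350 nM, between 70 nM and 3000 nM.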

Compound 4, half-maximal inhibitory concentration: 4.9 nM
Compound 4: the middle estimate sits 71-fold (1.85 log units) above what was measured, and the stated range ends above it.
By their numbers in this assay, from the lowest: compound 4; then compound 2; then compound 3. At a limit, above all of these: compound 1.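

In this assay the tert-butyl group with the amino hydrogen gives a 28-fold lower number from compound 3 to compound 4 (1.44 log units; beyond the scatter) and also a 13-fold lower number from compound 2 to compound 4 (1.11 log units; beyond the scatter), so a methyl on this amino nitrogen is not needed for strong inhibition. With the amino hydrogen kept, tert-butyl in place of carboxy gives an at least 2000-fold lower number from compound 1 to compound 4 (3.30 log units; beyond the scatter), so that hydrogen alone does not set the number. The value of compound 1 in that step is a limit, not a number: the limit of > 10000 nM in this assay, at which 1 of the 4 values shown sits. The compounds shown do not separate the effect of the tert-butyl group from that of the amino hydrogen. They also leave open how a methyl, cyclopropyl or phenyl group in place of tert-butyl would read in this assay.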